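Compound 2 to compound 4: 3-fluorobenzyl to 4-methylbenzyl

This account rests on a few compounds, and the source may have more. Where it says the series, first, only, none or still open, it means among the compounds named here.

In an ADME assay on HEK-293T cells (Homo sapiens) for inhibition, read by CCK-8 assay, with a stated time of 48 h, tested at 20 uM (on this read-out lower numbers stand for less inhibition of growth and higher numbers for more inhibition of growth at the one concentration tested), compound 1 (`N#C/C(=C\c1ccccc1OS(=O)(=O)c1ccc([N+](=O)[O-])cc1)C(=O)Nc1nnc(Cc2cccc(F)c2)s1`) is entered as "not toxic" (no number reported) without a figure. Compound 2 (`N#C/C(=C\c1ccccc1OS(=O)(=O)c1ccccc1[N+](=O)[O-])C(=O)Nc1nnc(Cc2cccc(F)c2)s1`) is entered the same way as "not toxic" (no number reported) and so has no position on the numeric scale. It shares this status with compound 1. Compound 3 (`N#C/C(=C\c1ccccc1OS(=O)(=O)c1ccc(F)cc1)C(=O)Nc1nnc(Cc2cccc(F)c2)s1`) gives 17% as the only figure in the series.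

Compound 4 (`Cc1ccc(Cc2nnc(NC(=O)/C(C#N)=C/c3ccccc3OS(=O)(=O)c3ccccc3[N+](=O)[O-])s2)cc1`) awaits measurement. Going by the values given here, its one structural change is 4-methylphenyl in place of 3-fluorophenyl on a saturated chain carbon bound to an aromatic carbon with 4-methylphenyl in place of 3-fluorophenyl on a saturated chain carbon bound to an aromatic carbon. Among the compounds with values here, no measured pair isolates this change, so no observed step can size it. In this assay no step beyond the usual scatter is expected in either direction, and compound 3 at 17% is the only numeric reference. A report without a figure, as for compound 2, remains possible. For compound 4 the expected value is 15% with an estimated range of 0% to 35% at the single concentration tested.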

Compound 4, percent growth inhibition at one concentration: 6%
The estimate for compound 4 lay 9 percentage points above the measured number, and the stated range covers the measured number.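

Compound 2 stands as "not toxic" (no number reported) and compound 4 at 6%, so no step can be read between them. The compounds shown leave open the size of the change from 3-fluorobenzyl to 4-methylbenzyl on growth inhibition. No supporting evidence bears on this result.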